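The source may hold more compounds than are shown below. What is called first, only, known or untested is meant among the compounds shown, and "the series" means these compounds.

In a functional assay on PC-3 cells (Homo sapiens) for antiproliferative activity, read by MTT assay, with a stated time of 48 h (on this read-out higher numbers stand for weaker inhibition and lower numbers for stronger inhibition), compound 1 `CN1C(=O)C2(C(C#N)=C(N)Oc3cc4oc(-c5ccccc5)cc(=O)c4c(O)c32)c2cc(Cl)ccc21` gives 21400 nM and compound 2 `CN1C(=O)C2(C(C#N)=C(N)Oc3cc4oc(-c5ccccc5)cc(=O)c4c(O)c32)c2cc(Br)ccc21` gives 20300 nM, so compound 2 stands level with compound 1. Compound 3 `N#CC1=C(N)Oc2cc3oc(-c4ccccc4)cc(=O)c3c(O)c2C12C(=O)N(Cc1ccccc1)c1ccc(Br)cc12` differs from compound 2 by phenyl in place of hydrogen on a saturated chain carbon bound to an amide-type nitrogen in a ring, which reads as methyl to benzyl. Among the measured compounds shown here, the only measured step, a 1.1-fold lower number from compound 1 to compound 2 (0.02 log units; within the scatter), is bromo in place of chloro on an aromatic carbon and sets no size for this change. With compound 2 at 20300 nM as the anchor, no step beyond the scatter is expected in this assay. The estimated step is a 1.4-fold lower number from compound 2 to compound 3 (0.13 log units; within the scatter). Compound 3 is estimated at 15000 nM, with an expected range of 5500 nM to 38000 nM.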

Compound 3, half-maximal inhibitory concentration: > 50000 nM
Compound 3: no number, only a limit (the forecaster's own chance of this, stated with the estimate: 10%); at least 3.3-fold (0.52 log units) between middle value and limit.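

Methyl to benzyl at this place, a saturated chain carbon bound to an amide-type nitrogen in a ring, gives an at least 2.4-fold higher number from compound 2 to compound 3 (0.39 log units; beyond the scatter) in this assay, the first change in the series to move the read-out beyond the scatter. This position therefore responds towards weaker inhibition, whereas bromo in place of chloro on an aromatic carbon stayed within the scatter. The step has no upper end, since compound 3 gives only a limit of the assay: the limit of > 50000 nM in this assay, at which 1 of the 3 values shown sits.

Going by these compounds, whether an ethyl group, a longer chain without phenyl, or a chain ending in an amine would read like methyl or like benzyl stays open.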